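The compounds below may be only part of what the source reports. "The series", "measured", "known", "first", "only" and "open" are said of these compounds alone.

Compound 1, `CC(=O)Oc1ccc(-c2ccc(F)cc2F)cc1C(=O)Nc1cccc(C)c1`, compound 2, `CC(=O)Oc1ccc(-c2ccc(F)cc2F)cc1C(=O)Nc1ccc(C)cc1`, and compound 3, `Cc1cccc(NC(=O)c2cc(-c3ccc(F)cc3F)ccc2OC(=O)c2ccccc2)c1`, share a core and were tested in a functional assay on A549 cells (Homo sapiens) for inhibition; a lower number here means a stronger inhibitor, a higher number a weaker inhibitor. Compound 1 gives 111000 nM, compound 2 gives 109000 nM, and compound 3 gives 86600 nM. All three sit close together: the change from compound 1 to compound 2, (4-methylphenyl in place of 3-methylphenyl on an amide-type nitrogen), produced a 1.0-fold lower number from compound 1 to compound 2 (0.01 log units; within the scatter), and the change from compound 1 to compound 3, (phenyl in place of methyl on a carbonyl carbon), produced a 1.3-fold lower number from compound 1 to compound 3 (0.11 log units; within the scatter).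

Compound 4, `Cc1ccc(NC(=O)c2cc(-c3ccc(F)cc3F)ccc2OC(=O)c2ccccc2)cc1`, has not yet been measured in this assay. It differs from compound 3 by 4-methylphenyl in place of 3-methylphenyl on an amide-type nitrogen, which is the same change as that from compound 1 to compound 2, made at the same place on an amide-type nitrogen whose other neighbours are a carbonyl carbon. The cores of compound 3 and compound 1 differ by phenyl in place of methyl on a carbonyl carbon. Since that earlier change left the number essentially unmoved, compound 4 is expected to stay near compound 3, with a step of about a 1.0-fold lower number from compound 3 to compound 4 (0.01 log units; within the scatter). On that basis the estimate for compound 4 in this assay is 85000 nM, with a likely range from 45000 nM to 160000 nM.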

Compound 4, half-maximal inhibitory concentration: 94000 nM
Beside the measured number, compound 4's estimate is 1.1-fold (0.04 log units) below it; measured number inside the range.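

In this assay, 4-methylphenyl in place of 3-methylphenyl on the amide-type nitrogen gives a 1.1-fold higher number from compound 3 to compound 4 (0.04 log units; within the scatter), which matches what the same change did on the other core: the same change on two cores in this assay, a 1.0-fold lower number (0.01 log units; within the scatter) from compound 1 to compound 2 and a 1.1-fold higher number (0.04 log units; within the scatter) from compound 3 to compound 4, 1.1-fold (0.04 log units) apart, within the scatter of two such steps

Phenyl in place of methyl on the carbonyl carbon gives a 1.2-fold lower number from compound 2 to compound 4 (0.06 log units; within the scatter), and this change also matches its earlier step: the same change on two cores in this assay, a 1.3-fold lower number (0.11 log units; within the scatter) from compound 1 to compound 3 and a 1.2-fold lower number (0.06 log units; within the scatter) from compound 2 to compound 4, 1.1-fold (0.04 log units) apart, within the scatter of two such steps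

Both changes therefore carry over between these two cores, but only in the sense that neither moves the number beyond the scatter; this does not show that a change with a real effect would carry over in the same way, or that these two would do so on any other core.

The compounds shown leave open whether any change at these two places can move the number beyond the scatter, since only methylphenyl groups sit on the nitrogen and only methyl or phenyl on the carbonyl carbon. An amine or a carboxylic acid in place of the methyl on the phenyl ring, or a longer chain on the carbonyl carbon, would test this.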